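The source may hold more compounds than are shown below. What is called first, only, known or untested is meant among the compounds shown, and "the series" means these compounds.

Compound 1 `CN1CCN(c2ccc(Nc3ncc4nc([S+]([O-])c5ccccc5)n(C5CCOCC5)c4n3)cc2)CC1`: 411 nM
Compound 2 `CC(C)n1c([S+]([O-])c2ccccc2)nc2cnc(Nc3ccc(N4CCN(C)CC4)cc3)nc21`: 215 nM

Of the two compounds measured in a functional assay on HCC827 cells (Homo sapiens) for antiproliferative activity, read by MTT assay, with a stated time of 72 h (a higher number here means a weaker inhibitor, a lower number a stronger inhibitor), compound 1 gives the highest number, with compound 2 the nearest, a step of a 1.9-fold lower number from compound 1 to compound 2 (0.28 log units; within the scatter), which arose from isopropyl in place of oxan-4-yl on an aromatic nitrogen. Compound 3 `CN1CCN(c2ccc(Nc3ncc4nc(SCc5cccnc5)n(C5CCOCC5)c4n3)cc2)CC1` differs from compound 1 at another place: a group of 8 heavy atoms (6 carbon, 1 nitrogen, 1 sulfur; one six-membered aromatic ring with 1 hetero atom) in place of a group of 8 heavy atoms (6 carbon, 1 oxygen, 1 sulfur; one six-membered aromatic ring of carbon only), on an aromatic carbon. Going by the values given here, no measured step touches this position, so there is no direct precedent; the one available step was within the scatter. The author therefore expects compound 3 to show a 1.0-fold lower number from compound 1 to compound 3 (0.01 log units; within the scatter), an estimate of 400 nM with a range of 130 nM to 1300 nM.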

Compound 3, half-maximal inhibitory concentration: 500 nM
Compound 3: middle estimate off by 1.3-fold (0.10 log units), on the low side, within the range that was stated.
By their numbers in this assay, from the lowest: compounds 2, 1 and 3 (each within the scatter of the next, the first and the last beyond it).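

At this position, on the aromatic carbon between two ring nitrogen atoms, ((pyridin-3-yl)methyl)sulfanyl replaces the group with the carbon-only aromatic ring, and this assay shows a 1.2-fold higher number from compound 1 to compound 3 (0.09 log units; within the scatter). This first step at the position leaves the number within the scatter, so the exchange of these two groups is tolerated here. No other data available here bear on this result.

Still open, going by these compounds, is whether an amine or a carboxylic acid on the pyridine ring, or a longer chain to that ring, would move the number beyond the scatter. Also open, on these data alone, is whether the same exchange behaves alike with isopropyl on the ring nitrogen.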